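The source may report more compounds than this note shows. Statements on the series, on what has been measured and on what is new or still open speak of the compounds shown alone.

Compound 1 `CCC(=O)NCCCO[C@H]1[C@H](O[C@@H]2[C@@H](C)[C@H](O[C@H]3C[C@@](C)(OC)[C@@H](O)[C@H](C)O3)[C@@H](C)C(=O)O[C@H](CC)[C@@](C)(O)[C@H](O)[C@@H](C)N(C)C[C@H](C)C[C@@]2(C)O)O[C@H](C)C[C@@H]1N(C)C` is one of two macrolides measured in a physicochemical assay for lipophilicity, read by HPLC, measured as chromatographic lipophilicity, at pH 7.4; a higher number here means a more lipophilic compound, a lower number a more polar compound. In this assay, going by the values given here, compound 1 gives 2.7, which is the lower of the two numbers known so far. The other measured compound, compound 2 `CCCCC(=O)NCCCO[C@@H]1[C@@H](C)N(C)C[C@H](C)C[C@@](C)(O)[C@H](O[C@@H]2O[C@H](C)C[C@H](N(C)C)[C@H]2O)[C@@H](C)[C@H](O[C@H]2C[C@@](C)(OC)[C@@H](O)[C@H](C)O2)[C@@H](C)C(=O)O[C@H](CC)[C@@]1(C)O`, carries a pentanoylamino chain and in this assay gives 3.74, a value that lies above that of compound 1 by more than the usual scatter. Among the compounds with values here, no single-change pair links compound 1 and compound 2, so the two values can only be set side by side.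

The compound not yet measured is compound 3 `CC[C@H]1OC(=O)[C@H](C)[C@@H](O[C@H]2C[C@@](C)(OC)[C@@H](O)[C@H](C)O2)[C@H](C)[C@@H](O[C@@H]2O[C@H](C)C[C@H](N(C)C)[C@H]2OCCCNC(=O)c2c(C)nn(C)c2Cl)[C@](C)(O)C[C@@H](C)CN(C)[C@H](C)[C@@H](O)[C@]1(C)O`. It departs from compound 1 at a single point: 5-chloro-1,3-dimethyl-1H-pyrazol-4-yl in place of ethyl on a carbonyl carbon. In this assay a step from compound 1 to compound 3 of modest size is expected, directed towards a higher number, since a ring of eight heavy atoms with a chlorine replaces a two-carbon ethyl while the two added hydrogen-bond acceptors temper the rise; this step is estimated as a number 0.60 log units higher from compound 1 to compound 3 (beyond the scatter). Compound 3 is therefore expected to give about 3.3 in this assay, within a range from 2.7 to 3.9.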

Compound 3, distribution coefficient: 3.08
For compound 3 the middle estimate is 0.22 log units above the measured one; the measured number falls inside the stated range.
By their numbers in this assay, from the lowest: compound 1; then compound 3; then compound 2.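

The earlier compounds shown here gave no single-change step at this position, and compound 3 supplies the first: in this assay, 5-chloro-1,3-dimethyl-1H-pyrazol-4-yl in place of ethyl on a carbonyl carbon, whose other neighbour is the amide-type nitrogen, gives a number 0.38 log units higher from compound 1 to compound 3 (beyond the scatter). The position therefore responds measurably to this change, and the exchange of a small open chain for a substituted five-membered aromatic ring with 2 hetero atoms produces a shift that is modest in size and lies beyond the usual scatter. Nothing at hand bears on what lies behind this shift.

The compounds shown do not separate the share of the chlorine from that of the two methyl groups or of the ring itself, since all of them enter together in this single change. Also open, as far as these compounds go, is how the number in this assay would move with a phenyl ring, a carboxylic acid or a primary amine on the same carbonyl carbon, and whether any of these would shift it in the same direction.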